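Ether Aryl Swap on a Shared Core: Compound 4

The source may hold more compounds than are shown below. What is called first, only, known or untested is meant among the compounds shown, and "the series" means these compounds.

Measured compounds:
compound 1 `Cc1nn(-c2ncnc3nc[nH]c23)c2c1C(OCc1ccccc1C#N)CC(=O)N2` gives 8 nM
compound 2 `Cc1nn(-c2ncnc3nc[nH]c23)c2c1C(C(=O)NCc1ccccc1)CC(=O)N2` gives 5 nM
compound 3 `Cc1nn(-c2ncnc3nc[nH]c23)c2c1C(NC(=O)c1ccccc1)CC(=O)N2` gives 3 nM

These three compounds share one core and differ only in the group on a saturated ring carbon. In a functional assay on HEK293 cells for agonist activity at G-protein coupled receptor 39 (Homo sapiens), read by scintillation proximity assay and inositol phosphate accumulation, with a stated time of 75 min, in the presence of a further agent that is not named here (on this read-out lower numbers stand for an effect already at smaller amounts and higher numbers for an effect only at larger amounts of compound), compound 1 stands at the highest of the three numbers. Its nearest neighbour is compound 2, with a 1.6-fold lower number from compound 1 to compound 2 (0.20 log units; within the scatter). The gap to compound 3 is larger, a 2.7-fold lower number from compound 1 to compound 3 (0.43 log units; beyond the scatter), and the step between those two, a 1.7-fold lower number from compound 2 to compound 3 (0.22 log units; within the scatter), is small.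

Compound 4 `Cc1nn(-c2ncnc3nc[nH]c23)c2c1C(OCc1cc(F)cc3c1OCOC3)CC(=O)N2` keeps the oxygen link of compound 1 and exchanges the aryl part: a group of 11 heavy atoms (8 carbon, 2 oxygen, 1 fluorine; one six-membered non-aromatic ring with 2 hetero atoms, one six-membered aromatic ring of carbon only) in place of a group of 8 heavy atoms (7 carbon, 1 nitrogen; one six-membered aromatic ring of carbon only), on a saturated chain carbon bound to an oxygen on a saturated carbon. For the measured compounds named here, no measured step keeps the ether and changes only the aryl; the two steps from compound 1 both replace the whole group with an amide and move the number down by little or modestly. All three groups at this position give numbers in one narrow band, so the change in compound 4 is expected to bring no step beyond the scatter, with a 1.1-fold lower number from compound 1 to compound 4 (0.06 log units; within the scatter) as the expected outcome. Compound 4 is therefore estimated at 7 nM, in a range from 2.5 nM to 20 nM.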

Compound 4, half-maximal effective concentration: 1.5 nM
The estimate for compound 4 lay 4.7-fold (0.67 log units) above the measured number; measured number outside the range, below it.
By their numbers in this assay, from the lowest: compounds 4, 3, 2 and 1 (each within the scatter of the next, the first and the last beyond it).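

With the oxygen link held in place, the aryl part alone moves the number in this assay: the entering group, with its fluorine and its six-membered non-aromatic ring with 2 hetero atoms, gives a 5.3-fold lower number from compound 1 to compound 4 (0.73 log units; beyond the scatter) and replaces 2-cyanophenyl. The earlier steps shown here beyond the scatter at this position exchanged the whole group for an amide, whereas this one shows that a compound with the ether link can share a level with an amide, since compound 4 at 1.5 nM and compound 3 at 3 nM lie within the scatter of each other. Nothing available explains the step from compound 1 to compound 4.

The exchange changes the nitrile, the fluorine and the second ring together, so the compounds shown leave open which of these parts carries the step, and a plain phenyl or a 3-fluorophenyl on the same ether link would separate them. They also leave open whether the entering group keeps this level on an amide link like that of compound 3, or on a longer chain in place of the oxygen link.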